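This account rests on a few compounds, and the source may have more. Where it says the series, first, only, none or still open, it means among the compounds named here.

Results in a functional assay on MCF7 cells (Homo sapiens) for antiproliferative activity, read by MTT assay, with a stated time of 24 h; a lower number here means a stronger inhibitor, a higher number a weaker inhibitor:
compound 1 `Oc1cccc(-c2nnc(Nc3cccc(F)c3)s2)c1` gives 140000 nM
compound 2 `Fc1cccc(Nc2nnc(-c3cccc(Cl)c3)s2)c1` gives > 200000 nM, which is a limit
compound 3 `Clc1ccc(-c2nnc(Nc3ccc(Br)cc3)s2)c(Cl)c1` gives 120000 nM

Compound 3 at 120000 nM lies within the scatter of compound 1 at 140000 nM. Compound 2 stands only as a limit, > 200000 nM.

Compound 4 `Fc1ccc(Nc2nnc(-c3ccc(Cl)cc3Cl)s2)cc1` differs from compound 3 by a single change, fluoro in place of bromo on an aromatic carbon, para to a large group (fluoro in place of bromo on an aromatic carbon). Going by the values given here, no measured step makes this exchange. Among the compounds with values here, the only step available, an at least 1.4-fold higher number from compound 1 to compound 2 (0.15 log units; that floor lies within the scatter), is a different exchange, chloro in place of hydroxy on an aromatic carbon, and its floor lies within the scatter. No shift beyond the scatter is therefore expected in this assay, although a reading could also stop at the limit of > 200000 nM in this assay, at which 1 of the 3 values shown sits. The expectation rests on compound 3 at 120000 nM. The expected size of the change is a 1.1-fold higher number from compound 3 to compound 4 (0.03 log units; within the scatter). For compound 4 the estimated value is 130000 nM, with an expected range from 80000 nM to 200000 nM.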

Compound 4, half-maximal inhibitory concentration: 160000 nM
Beside the measured number, compound 4's estimate is 1.2-fold (0.09 log units) below it; measured number inside the range.
By their numbers in this assay, from the lowest: compounds 3, 1 and 4 (each within the scatter of the next). At a limit, above all of these: compound 2.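

In this assay, the exchange of bromo for fluoro on the aromatic carbon gives a 1.3-fold higher number from compound 3 to compound 4 (0.12 log units; within the scatter), so the 4-bromophenyl and 4-fluorophenyl groups cannot be told apart here. Going by these compounds alone, the only earlier step concerned a different exchange at another place and ended in a limit, whereas this step has a number at both ends. It shows that one halogen can replace the other at this position, para to a large group, without a shift beyond the scatter.

On these data alone, whether a group that is not a halogen, such as an amine or a methoxy group, would move the number at this position stays open. Any such reading would also have to be set against a series in which compound 2 stands only as a limit: the limit of > 200000 nM in this assay, at which 1 of the 4 values shown sits.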